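The source may report more compounds than this note shows. Statements on the series, on what has been measured and on what is new or still open speak of the compounds shown alone.

Compound 1 `CCCCSC(=S)C1=C(Nc2ccc(Cl)cc2Cl)CC(C)(C)CC1=O` was tested in a functional assay on PBMC cells (Homo sapiens) for inhibition, read by thymidine incorporation, with a stated time of 72 h; a lower number here means a stronger inhibitor, a higher number a weaker inhibitor. In this assay compound 1 gives > 50 ug/mL, which is a limit of the assay rather than a measured number. Compound 2 `CC1(C)CC(=O)C(C(=S)SCc2ccccc2)=C(Nc2ccc(Cl)cc2Cl)C1` was measured in the same assay, and there compound 2 gives > 50 ug/mL, again a limit. Compound 3 `CC1(C)CC(=O)C(C(=S)SCCO)=C(Nc2ccc(Cl)cc2Cl)C1` likewise gives > 50 ug/mL in this assay, also a limit. Accordingly, the three measured steps are a step that the two limits leave unreadable from compound 1 to compound 2, a step that the two limits leave unreadable from compound 1 to compound 3 and a step that the two limits leave unreadable from compound 2 to compound 3; none of them can be read as a number, since (the limit of > 50 ug/mL in this assay, at which 3 of the 3 values shown sit).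

The compound now in question is compound 4 `CCCCSC(=S)C1=C(Nc2ccc(Br)cc2)CC(C)(C)CC1=O`, which differs from compound 1 by 4-bromophenyl in place of 2,4-dichlorophenyl on an amine nitrogen. Going by the values given here, none of the measured steps alters the group on the amine nitrogen, so none of them bears directly on this change; what they show is only that every measured compound sits at the limit of this assay. With no readable step to draw on, the expectation for compound 4 in this assay is simply that it remains at the same limit, so the step that the limit leaves unreadable from compound 1 to compound 4 is expected to be nothing readable. Compound 4 is therefore estimated at 60 ug/mL, with a range from 20 ug/mL to 200 ug/mL.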

Compound 4, half-maximal inhibitory concentration: > 50 ug/mL
Compound 4: no number, only a limit (the forecaster's own chance of this, stated with the estimate: 80%); the middle value is on the limit's open side.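

Compound 4, like compound 1, gives only a limit in this assay, so no step between the two can be read: the limit of > 50 ug/mL in this assay, at which 4 of the 4 values shown sit.

The compounds shown leave open how strongly any of the four inhibits in this assay, and whether the group on the amine nitrogen or on the sulfur affects that inhibition at all.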